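A few compounds are considered here, and "the series" means these few. Any claim that something is new, unique, unknown or untested is made for them only; others in the source may bear on it.

Measured in a functional assay on DU-145 cells (Homo sapiens) for inhibition, read by trypan blue exclusion, with a stated time of 96 h; a lower number here means a stronger inhibitor of growth, a higher number a weaker inhibitor of growth:
- Compound 1 `O=C(O)c1ccc(C(=O)/C(=C\c2ccc(Br)c([N+](=O)[O-])c2)SCc2ccccc2Cl)cc1`: 1000 nM
- Compound 2 `Cc1ccc(CS(=O)(=O)/C(=C/c2ccc(Br)cc2)C(=O)c2ccc(Cl)cc2)cc1`: 25000 nM

Compound 2 holds the higher of these two numbers, and the gap to compound 1 lies beyond the scatter. The two compounds differ in more than one place, so their gap cannot be tied to any single group.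

Compound 3 `CCOc1ccc(/C=C(\C(=O)c2ccc(Cl)cc2)S(=O)(=O)Cc2ccc(C)cc2)cc1OC` departs from compound 2 in one place: 4-ethoxy-3-methoxyphenyl in place of 4-bromophenyl on a double-bonded chain carbon bound to a double-bonded chain carbon. It carries 4-ethoxy-3-methoxyphenyl in place of 4-bromophenyl on a double-bonded chain carbon bound to a double-bonded chain carbon.

Going by the values given here, no measured pair isolates this exchange, so only a modest move toward a lower number is expected, about at the edge of the scatter. The estimated change is a 2.1-fold lower number from compound 2 to compound 3 (0.32 log units; beyond the scatter). For compound 3 the expected value is 12000 nM, with an estimated range of 3000 nM to 40000 nM.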

Compound 3, concentration for 50% growth inhibition: 10000 nM
Beside the measured number, compound 3's estimate is 1.2-fold (0.08 log units) above it, and the stated range covers the measured number.
By their numbers in this assay, from the lowest: compound 1; then compound 3; then compound 2.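

In this assay, going by these compounds alone, the exchange of 4-bromophenyl for 4-ethoxy-3-methoxyphenyl on a double-bonded chain carbon bound to a double-bonded chain carbon gives a 2.5-fold lower number from compound 2 to compound 3 (0.40 log units; beyond the scatter) and is the first change here that can be tied to a single place. This position therefore accepts the larger group, with its two hydrogen-bond acceptors and no bromine, and growth inhibition becomes modestly stronger rather than being lost. No measurement shown here accounts for the step.

The compounds shown leave open how much of the step belongs to losing the bromine and how much to gaining the ethoxy or the methoxy group, since the exchange changes all of these together. They also do not show how a phenyl bearing a hydroxyl or an amine would behave at this place.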